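The source may report more compounds than this note shows. Statements on the series, on what has been measured and on what is new or still open speak of the compounds shown alone.

Three anilines on the shared core have numbers in an assay on FRT-Jurkat cells for inhibition of nuclear factor NF-kappa-B complex (Homo sapiens), read by flow cytometry, with a stated time of 24 h, tested at 10 uM; on this read-out lower numbers stand for less inhibition and higher numbers for more inhibition at the one concentration tested (going by the name of the read-out). Compound 1 `COc1ccc(Nc2cccc3c2C(=O)N(C2CCC(=O)NC2=O)C3=O)cc1` gives 13%, compound 2 `CCCCCc1ccc(Nc2cccc3c2C(=O)N(C2CCC(=O)NC2=O)C3=O)cc1` gives 23%, and compound 3 `CC(C)(C)c1ccc(Nc2cccc3c2C(=O)N(C2CCC(=O)NC2=O)C3=O)cc1` gives 36%, the highest of the three; its gaps, a number 23 percentage points higher from compound 1 to compound 3 (beyond the scatter) and a number 13 percentage points higher from compound 2 to compound 3 (beyond the scatter), both lie beyond the scatter, whereas a number 10 percentage points higher from compound 1 to compound 2 (within the scatter) does not. Compound 4 `CC(C)c1ccc(Nc2cccc3c2C(=O)N(C2CCC(=O)NC2=O)C3=O)cc1` differs from compound 3 by hydrogen in place of methyl on a saturated chain carbon bound to an aromatic carbon and two saturated chain carbons. For the measured compounds named here, no measured step removes a methyl from such a chain carbon, so only the two steps ending in the tert-butyl compound bear on it, and they show that the full tert-butyl group carried the highest number. Trimming it to isopropyl is expected to cost a little, a number 7 percentage points lower from compound 3 to compound 4 (within the scatter), probably within the scatter. Compound 4 is therefore estimated at 29%, with a range of 15% to 42%.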

Compound 4, a percentage reported as inhibition, at one concentration (the size of the read-out at that concentration, not a potency): 19%
Compound 4: middle estimate off by 10 percentage points, on the high side, and the stated range covers the measured number.
By their numbers in this assay, from the lowest: compounds 1, 4 and 2 (each within the scatter of the next); then compound 3.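

Removing a single methyl from the tert-butyl group is enough to give a step beyond the scatter (a number 17 percentage points lower from compound 3 to compound 4 (beyond the scatter)), so isopropyl does not stand in for tert-butyl at this position. Isopropyl stays within the scatter of both pentyl (a number 4 percentage points lower from compound 2 to compound 4 (within the scatter)) and methoxy (a number 6 percentage points higher from compound 1 to compound 4 (within the scatter)), which leaves compound 3 alone above the other three. Nothing measured here explains why this one methyl matters.

Still open, on these data alone, is whether trifluoromethyl in place of one methyl of the tert-butyl group would keep the higher number. A cyclopropyl or cyclohexyl group on the same aromatic carbon is equally untested by these compounds.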